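Extending the Linker Toward a Benzamide Cap

The compounds below may be only part of what the source reports. "The series", "measured", "known", "first", "only" and "open" are said of these compounds alone.

Compound 1 `CCOc1cc(C(C)(C)C)ccc1C1=NC(c2ccc(Cl)cc2)C(c2ccc(Cl)cc2)N1C(=O)N1CCN(Cc2ccc(C(=O)NO)cc2)CC1` — 3000 nM
Compound 2 `CCOc1cc(C(C)(C)C)ccc1C1=NC(c2ccc(Cl)cc2)C(c2ccc(Cl)cc2)N1C(=O)NCCCCC(=O)Nc1ccccc1N` — 15600 nM

In a functional assay on NCI-H1299 cells (Homo sapiens) for antiproliferative activity, read by CCK-8 assay, with a stated time of 72 h (on this read-out lower numbers stand for stronger inhibition and higher numbers for weaker inhibition), compound 1 gives 3000 nM, while compound 2 gives 15600 nM, the higher of the two numbers, with compound 1 the nearer neighbour.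

Compound 3 `CCOc1cc(C(C)(C)C)ccc1C1=NC(c2ccc(Cl)cc2)C(c2ccc(Cl)cc2)N1C(=O)NCCCCCCC(=O)Nc1ccccc1N` differs from compound 2 only in the chain: 2-((2-aminophenyl)carbamoyl)ethyl in place of (2-aminophenyl)carbamoyl on a saturated chain carbon, four bonds along the chain from an amide-type nitrogen. For the measured compounds named here, no comparable step between measured compounds is available, so the effect of a longer chain is untested here. A modest move toward a lower number is expected, as a 2.2-fold lower number from compound 2 to compound 3 (0.35 log units; beyond the scatter), though the direction remains uncertain. Compound 3 is estimated at 7000 nM, within 2000 nM to 25000 nM.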

Compound 3, half-maximal inhibitory concentration: 17500 nM
Beside the measured number, compound 3's estimate is 2.5-fold (0.40 log units) below it; low and high end bracket the measured number.
By their numbers in this assay, from the lowest: compound 1; then compounds 2 and 3 (each within the scatter of the next).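

In this assay, placing 2-((2-aminophenyl)carbamoyl)ethyl where (2-aminophenyl)carbamoyl stood, on a saturated chain carbon four bonds along the chain from an amide-type nitrogen, gives a 1.1-fold higher number from compound 2 to compound 3 (0.05 log units; within the scatter). This single-place comparison shows that this extension of the chain leaves the number unchanged within the usual scatter. No available evidence bears on this result. On these data alone, whether a still longer chain or a shorter one would shift the number remains open, as does the effect of a carboxylic acid in place of the (2-aminophenyl)carbamoyl group.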